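The source may hold more compounds than are shown below. What is called first, only, known or untested is meant among the compounds shown, and "the series" means these compounds.

Measured in an in vitro functional assay on cells (Fibroblast) for agonist activity at Alpha-1D adrenergic receptor (Homo sapiens); on this read-out higher numbers stand for an effect only at larger amounts of compound and lower numbers for an effect already at smaller amounts:
compound 1 `Cn1ncnc1-c1ccccc1NCC1=NCCN1` — 63.1 nM
compound 2 `CCn1ncnc1-c1ccccc1NCC1=NCCN1` — 126 nM
compound 3 `CC(C)n1ncnc1-c1ccccc1NCC1=NCCN1` — 3160 nM

Compound 1 gives the lowest number of the three; compound 2 is nearest, with a 2.0-fold higher number from compound 1 to compound 2 (0.30 log units; within the scatter), and compound 3 furthest, with a 50-fold higher number from compound 1 to compound 3 (1.70 log units; beyond the scatter). Compound 4 `Cc1nc(-c2ccccc2NCC2=NCCN2)n(C)n1` is not yet measured in this assay; it differs from compound 1 by methyl in place of hydrogen on an aromatic carbon.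

Going by the values given here, none of the measured steps adds a methyl on a ring carbon; all three alter the group on the ring nitrogen of the shared core. There, the one-carbon step a 2.0-fold higher number from compound 1 to compound 2 (0.30 log units; within the scatter) stays within the scatter, whereas a 50-fold higher number from compound 1 to compound 3 (1.70 log units; beyond the scatter) and a 25-fold higher number from compound 2 to compound 3 (1.40 log units; beyond the scatter) are large. So the core of compound 1 accepts one added carbon on the ring nitrogen without a clear cost, but not two. The change to compound 4 adds a single carbon as well, at a different place, so the nearest guide is the step from compound 1 to compound 2, and a small step, if any beyond the scatter, is expected. Compound 4 is therefore estimated at 160 nM (range 50 nM to 500 nM), an expected 2.5-fold higher number from compound 1 to compound 4 (0.40 log units; beyond the scatter).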

Compound 4, half-maximal effective concentration: < 5020 nM
Compound 4 ended at the assay's limit; the forecaster's own chance of this, stated with the estimate: 3%; the middle value is on the limit's open side.
By their numbers in this assay, from the lowest: compounds 1 and 2 (each within the scatter of the next); then compound 3.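

Compound 4 stands at < 5020 nM, which is a limit of the assay and not a number. The step between compound 1 and compound 4 therefore cannot be read: the limit of < 5020 nM in this assay, at which 1 of the 4 values shown sits.

The compounds shown leave open how far methyl in place of hydrogen on an aromatic carbon moves the number from that of compound 1, and in which direction.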